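Methylsulfonyl for chloro on the benzamide ring

A few compounds are considered here, and "the series" means these few. Any claim that something is new, unique, unknown or untested is made for them only; others in the source may bear on it.

Compound 1: `O=C(Nc1ccc(Cl)c(-c2nnc3c(Cl)cccn23)c1)c1ccc(C(F)(F)F)cc1F`, 41200 nM in a functional assay on AN3-CA cells (Homo sapiens) for antiproliferative activity, read by MTT assay, with a stated time of 72 h; a lower number here means a stronger inhibitor, a higher number a weaker inhibitor
Compound 2: `O=C(Nc1ccc(Cl)c(-c2nnc3c(Cl)cccn23)c1)c1cccc(Cl)c1`, 68400 nM in this assay

Of the compounds shown here, two sharing the same core have been measured. In this assay compound 1 gives 41200 nM, and compound 2 gives 68400 nM. Compound 2 stands as the higher of the two numbers, but its gap to compound 1 lies within the scatter, so the two cannot be ordered against each other; both sit at weak inhibition.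

Compound 3, `CS(=O)(=O)c1cccc(C(=O)Nc2ccc(Cl)c(-c3nnc4c(Cl)cccn34)c2)c1`, has not yet been measured. It differs from compound 2 in one place: methylsulfonyl in place of chloro on an aromatic carbon. Among the measured compounds shown here, no measured pair shows this change, so nothing in the data fixes its size or direction in this assay.

Given that, the estimate for compound 3 rests on compound 2 alone, and the step from compound 2 to compound 3 is expected to stay within the scatter, a 1.1-fold lower number from compound 2 to compound 3 (0.06 log units; within the scatter). In this assay compound 3 is expected to give about 60000 nM, with a range from 15000 nM to 200000 nM.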

Compound 3, half-maximal inhibitory concentration: > 100000 nM
Compound 3: a limit, no number; the forecaster's own chance of this, stated with the estimate: 25%; middle value at least 1.6-fold (0.22 log units) from the limit.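

In this assay compound 3 gives > 100000 nM, which is a limit of the assay and not a number. Methylsulfonyl in place of chloro on this aromatic carbon, meta to a large group, is the first change at this position with a reading, and it gives an at least 1.4-fold higher number from compound 2 to compound 3 (0.16 log units; that floor lies within the scatter), so adding the two hydrogen-bond acceptors of methylsulfonyl brings no lower number, though only a floor of the step is known and its true size cannot be read. The reading of this change stops at the end of the assay's range, so the data cannot separate a small step from a large one: the limit of > 100000 nM in this assay, at which 1 of the 3 values shown sits.

The compounds shown leave open how an amine or a carboxylic acid at this same position would read in this assay, and so whether any group here gives a clearly lower number than chloro does. They also leave open whether methylsulfonyl would give a similar step on the benzamide ring of compound 1, where trifluoromethyl and fluoro stand in place of the single chloro.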